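Working notes: permeability of compound 3 in the nitrile series

This account rests on a few compounds, and the source may have more. Where it says the series, first, only, none or still open, it means among the compounds named here.

Compound 1 `Cn1cncc1CN1CC(N(CC2CCN(S(C)(=O)=O)CC2)S(=O)(=O)c2ccccn2)Cc2cc(C#N)ccc21` and compound 2 `Cn1cncc1CN1CC(N(CC2CCN(C(=O)N3CCCCC3)CC2)S(=O)(=O)c2ccccn2)Cc2cc(C#N)ccc21` share a core and have both been run in an ADME assay on Caco-2 cells (Homo sapiens) for permeability, in the apical to basolateral direction; on this read-out higher numbers stand for higher permeability and lower numbers for lower permeability. Compound 1 gives 0.1 10^-6 cm/s, the lower of the two numbers; compound 2 gives 0.6 10^-6 cm/s. Among the compounds with values here, the single measured step is a 6.0-fold higher number from compound 1 to compound 2 (0.78 log units; beyond the scatter).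

Compound 3 `Cn1cncc1CN1CC(N(Cc2cccc(-n3cccc3)c2)S(=O)(=O)c2ccccn2)Cc2cc(C#N)ccc21` has not yet been run in this assay. Its difference from compound 1 is 3-(1H-pyrrol-1-yl)phenyl in place of 1-(methylsulfonyl)piperidin-4-yl on a saturated chain carbon bound to a sulfonamide nitrogen. The measured step from compound 1 to compound 2 alters the same arm but keeps the piperidinyl portion, so it bears on compound 3 only loosely: it shows that a change on this arm moved the number beyond the scatter. Within the data shown here, no measured pair covers the pyrrolylphenyl replacement itself. The working expectation is an upward step, a 10-fold higher number from compound 1 to compound 3 (1.00 log units; beyond the scatter), of about the size already seen. Compound 3 is therefore estimated at 1 10^-6 cm/s, with a range from 0.3 10^-6 cm/s to 4 10^-6 cm/s.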

Compound 3, apparent permeability: 2.3 10^-6 cm/s
Compound 3: the middle estimate sits 2.3-fold (0.36 log units) below what was measured; low and high end bracket the measured number.
By their numbers in this assay, from the lowest: compound 1; then compound 2; then compound 3.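

Replacing 1-(methylsulfonyl)piperidin-4-yl with 3-(1H-pyrrol-1-yl)phenyl on a saturated chain carbon bound to a sulfonamide nitrogen gives a 23-fold higher number from compound 1 to compound 3 (1.36 log units; beyond the scatter) in this assay, so the number at this position can rise with no piperidine ring present. This step on the same arm is larger than a 6.0-fold higher number from compound 1 to compound 2 (0.78 log units; beyond the scatter), which kept the piperidine ring and changed only the group on its nitrogen. The data on hand offer no measurement that accounts for either rise.

The compounds shown leave open whether the pyrrole ring is needed for the higher number, or whether an unsubstituted phenyl on the same carbon would give a similar result. From the compounds shown here alone, how the number responds to a carboxylic acid or a dimethylamino group on that phenyl ring also remains open.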